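The compounds below may be only part of what the source reports. "The series", "measured", "known", "first", "only" and "open" are said of these compounds alone.

Compound 1 `O=C(O)CC/C=C\CO[C@H]1[C@@H](OCc2ccc(-c3ccccc3CO)cc2)CC[C@@H]1N1CCCCCC1` has the second highest number of the three measured here; in a functional assay for antagonist activity at thromboxane A2 receptor (Rattus norvegicus) (a higher number here means weaker binding, a lower number tighter binding), compound 1 gives 12.6 nM. Compound 2 `O=C(O)CC/C=C\CO[C@H]1C(OCc2ccc(-c3ccccc3CO)cc2)CC[C@@H]1N1CCCCCC1`, drawn without a configuration at one ring carbon, gives 6.31 nM, a change of a 2.0-fold lower number from compound 1 to compound 2 (0.30 log units; within the scatter). Compound 3 `O=C(O)CC/C=C\CO[C@H]1C(OCc2ccc(-c3ccccc3O)cc2)CC[C@@H]1N1CCCCCC1`, with a hydroxy instead of a hydroxymethyl, gives 20 nM, a step of a 3.2-fold higher number from compound 2 to compound 3 (0.50 log units; beyond the scatter). Compound 4 `O=C(O)CC/C=C\CO[C@H]1[C@@H](OCc2ccc(-c3ccc(CO)cc3)cc2)CC[C@@H]1N1CCCCCC1` keeps every atom of compound 1 but relocates the hydroxymethyl: 4-(hydroxymethyl)phenyl in place of 2-(hydroxymethyl)phenyl on an aromatic carbon, para to a large group. For the measured compounds named here, no measured step moves this group around its ring; the only guide is the modest step that altered the same group in compound 3. The number for compound 4 is therefore expected to shift by about a 2.0-fold higher number from compound 1 to compound 4 (0.30 log units; within the scatter). Compound 4 is estimated at 25 nM, within 6 nM to 100 nM.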

Compound 4, dissociation constant: 50.1 nM
Compound 4: middle estimate off by 2.0-fold (0.30 log units), on the low side, within the range that was stated.
By their numbers in this assay, from the lowest: compounds 2, 1 and 3 (each within the scatter of the next, the first and the last beyond it); then compound 4.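

Moving the hydroxymethyl around its ring, with no atom gained or lost, still registers in this assay: going to 4-(hydroxymethyl)phenyl gives a 4.0-fold higher number from compound 1 to compound 4 (0.60 log units; beyond the scatter) and so shows that where this group sits counts, not only which group is present. The earlier step to compound 3 changed the group itself and could not show this. Nothing measured here explains the shift.

Going by these compounds, it remains open whether an aminomethyl or a carboxylic acid on this ring would follow the same trend, and whether a longer chain such as hydroxyethyl would fare better or worse than the hydroxymethyl.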